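A methoxymethyl group in place of phenyl on the amide

The compounds below may be only part of what the source reports. "The series", "measured", "known", "first", "only" and "open" are said of these compounds alone.

Compound 1 `O=C(Nc1ccc(C(F)(F)F)cc1)c1cccc(Nc2ncc(F)c(Nc3ccc(F)cc3)n2)c1`: > 10000 nM
Compound 2 `O=C(Nc1cccc(Nc2ncc(F)c(Nc3ccc(F)cc3)n2)c1)c1ccccc1`: > 10000 nM
Compound 3 `COc1cc(NC(=O)c2cccc(Nc3ncc(F)c(Nc4ccc(F)cc4)n3)c2)cc(OC)c1`: 13700 nM

The three measured compounds share a core and differ only in the group carried on the amide-type nitrogen. In a functional assay on DU-145 cells (Homo sapiens) for antiproliferative activity, read by sulforhodamine B assay, with a stated time of 3 days (on this read-out higher numbers stand for weaker inhibition of growth and lower numbers for stronger inhibition of growth), compound 1 gives > 10000 nM, which is a limit of the assay and not a number. Compound 3 gives 13700 nM. The step that the limit leaves unreadable from compound 1 to compound 3 is therefore not readable. Compound 2 gives > 10000 nM, again a limit of the assay. For the measured compounds named here, with the limit of > 10000 nM in this assay, at which 2 of the 3 values shown sit, compound 2 stands where nothing separates it from compound 1, and compound 3 is the only numbered value near it.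

Compound 4 `COCC(=O)Nc1cccc(Nc2ncc(F)c(Nc3ccc(F)cc3)n2)c1` differs from compound 2 by methoxymethyl in place of phenyl on a carbonyl carbon. No measured step touches the carbonyl carbon; the single step shown, from compound 1 to compound 3, alters the group on the amide-type nitrogen and even that cannot be sized. Since every measured compound sits at or close to the limit, compound 4 is expected to stay in the same region, and the step that the limit leaves unreadable from compound 2 to compound 4 is estimated as one that cannot be called beyond the scatter. For compound 4 the estimate is 15000 nM, with a range of 5000 nM to 50000 nM.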

Compound 4, concentration for 50% growth inhibition: 4460 nM
Compound 4: the middle estimate sits 3.4-fold (0.53 log units) above what was measured, and the stated range ends above it.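

In this assay, the change from phenyl to methoxymethyl on a carbonyl carbon gives an at least 2.2-fold lower number from compound 2 to compound 4 (0.35 log units; beyond the scatter), the only step among these compounds whose size can be read at all. The step has a floor but no full size, as compound 2 carries a limit and not a number: the limit of > 10000 nM in this assay, at which 2 of the 4 values shown sit. Even so, the result shows that this carbonyl carbon does not need an aromatic ring for the activity seen here, since compound 4, with a methoxymethyl group that has no ring, gives 4460 nM.

The compounds shown cannot tell whether the gain follows from losing the phenyl ring, from the smaller group, or from the oxygen of the methoxymethyl group, and an ethyl group, which has no such oxygen, or a dimethylaminomethyl group at the same place would help to separate these. From the compounds shown here alone, how far the trend runs also stays open, as a longer chain such as methoxyethyl, or a carboxylic acid on this carbonyl side, could move the value either way.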